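Swapping the Amine on the Side Chain of Compound 3

The source may hold more compounds than are shown below. What is called first, only, known or untested is meant among the compounds shown, and "the series" means these compounds.

Three compounds share one core and differ mainly in the chain attached to the amide. Compound 1 `COc1cc2ncnc(N3CCCc4ccccc43)c2cc1NC(=O)C=C(C)C` gives 5410 nM in a functional assay on A549 cells (Homo sapiens) for antiproliferative activity, read by MTT assay, with a stated time of 72 h; on this read-out higher numbers stand for weaker inhibition and lower numbers for stronger inhibition. Among the measured compounds shown here, compound 3 `COc1cc2ncnc(N3CCCc4ccccc43)c2cc1NC(=O)/C=C/CN(C)C` gives 1650 nM in this assay, the lowest of the three numbers; the only single measured change, a 3.3-fold lower number from compound 1 to compound 3 (0.52 log units; beyond the scatter), connects these two. Compound 2 `COc1cc2ncnc(N3CCc4ccccc43)c2cc1NC(=O)/C=C/CN1CCCCC1` gives 2540 nM in this assay, a value within the scatter of compound 3, so no order can be drawn between them. Compound 4 `COc1cc2ncnc(N3CCCc4ccccc43)c2cc1NC(=O)/C=C/CN1CCCCC1` has not yet been measured. It differs from compound 3 by piperidin-1-yl in place of dimethylamino on a saturated chain carbon bound to a double-bonded chain carbon. For the measured compounds named here, no measured step covers this exact exchange; compound 2 carries the same piperidin-1-yl group but on a different core, so its value and that of compound 3 can only be set side by side, and they do not separate. The step of a 1.2-fold higher number from compound 3 to compound 4 (0.08 log units; within the scatter) is therefore expected to stay within the scatter. Compound 4 is estimated at 2000 nM, with a range from 900 nM to 4500 nM.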

Compound 4, half-maximal inhibitory concentration: 2880 nM
Compound 4: the middle estimate sits 1.4-fold (0.16 log units) below what was measured; measured number inside the range.
By their numbers in this assay, from the lowest: compounds 3, 2, 4 and 1 (each within the scatter of the next, the first and the last beyond it).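

In this assay the exchange of dimethylamino for piperidin-1-yl, now seen on one shared core, gives a 1.7-fold higher number from compound 3 to compound 4 (0.24 log units; within the scatter) and so leaves the two amines unseparated, even though the ring adds heavy atoms. The exchange of 2,3-dihydro-1H-indol-1-yl for 1,2,3,4-tetrahydroquinolin-1-yl gives a 1.1-fold higher number from compound 2 to compound 4 (0.05 log units; within the scatter) and does not separate those compounds either, while a 1.9-fold lower number from compound 1 to compound 4 (0.27 log units; within the scatter) stays within the scatter, unlike a 3.3-fold lower number from compound 1 to compound 3 (0.52 log units; beyond the scatter) on the same core. No measurement is available to explain these results.

On these data alone, it remains open whether a different ring amine on this chain, such as morpholin-4-yl or pyrrolidin-1-yl, would separate from dimethylamino. The compounds shown also cannot tell whether a longer chain between the double bond and the amine would move the number beyond the scatter.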